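The source may report more compounds than this note shows. Statements on the series, on what has been measured and on what is new or still open speak of the compounds shown alone.

Measured compounds:
compound 1 `OCCNc1nccc2c1ncn2C1O[C@H](CO)[C@@H](O)[C@H]1O`: 6%
compound 2 `c1ccc(Nc2[nH]ccc3ncnc2-3)cc1`: 26%
compound 3 `c1ccc(CNc2[nH]ccc3ncnc2-3)cc1`: 57%

All three were tested in a functional assay on EL4 cells (Mus musculus) for inhibition, tested at 100 uM; a higher number here means more inhibition at the concentration tested (going by the name of the read-out), a lower number less inhibition. Compound 1 stands lowest of the three: compound 2 is the nearest, its number higher by more than the usual scatter, and compound 3 is the furthest, higher still by a margin well beyond the scatter. Compound 4 `OC[C@H]1OC(n2cnc3c(NCc4ccccc4)nccc32)[C@H](O)[C@@H]1O` has not yet been measured in this assay. It differs from compound 1 in one place: phenyl in place of hydroxymethyl on a saturated chain carbon bound to a nitrogen on an aromatic ring. Because compound 3, which carries a benzylamino group, gives 57%, an increase beyond the scatter is expected, estimated as a number 24 percentage points higher from compound 1 to compound 4 (beyond the scatter). Compound 4 is accordingly expected to give 30%, with a likely range from 5% to 60%.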

Compound 4, a percentage reported as inhibition, at one concentration (the size of the read-out at that concentration, not a potency): 5%
Compound 4: the middle estimate sits 25 percentage points above what was measured, and the stated range covers the measured number.
By their numbers in this assay, from the lowest: compounds 4 and 1 (each within the scatter of the next); then compound 2; then compound 3.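

Replacing hydroxymethyl with phenyl on a saturated chain carbon bound to a nitrogen on an aromatic ring gives a number 1 percentage points lower from compound 1 to compound 4 (within the scatter) in this assay. On the core of compound 1, then, 2-hydroxyethyl and benzyl cannot be told apart at this position: phenyl brings no measurable gain in inhibition, and losing the hydroxymethyl brings no measurable loss. No measurement shown here offers an explanation for this result.

From the compounds shown here alone, it remains open whether an amine, a carboxylic acid or a longer chain ending in phenyl would shift the number at this position. Whether any group here can raise inhibition on this core also stays unanswered.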